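The source may report more compounds than this note shows. Statements on the series, on what has been measured and on what is new or still open speak of the compounds shown alone.

Three compounds share one core and differ only in the group on the amide-type nitrogen. Their numbers in a functional assay on HT-29 cells (Homo sapiens) for cytotoxicity, read by MTT assay, with a stated time of 72 h (on this read-out lower numbers stand for stronger inhibition and higher numbers for weaker inhibition), are:

compound 1 `O=C(CN1CCN(c2nnc(Cc3ccncc3)c3ccccc23)CC1)Nc1ccc(F)c(F)c1` — 2320 nM
compound 2 `O=C(CN1CCN(c2nnc(Cc3ccncc3)c3ccccc23)CC1)Nc1cccc(Br)c1` — 1350 nM
compound 3 `O=C(CN1CCN(c2nnc(Cc3ccncc3)c3ccccc23)CC1)Nc1ccc(F)c(C(F)(F)F)c1` — 1110 nM

Compound 3 gives the lowest of the three numbers in this assay, yet only its gap to compound 1 is beyond the scatter: a 2.1-fold lower number from compound 1 to compound 3 (0.32 log units; beyond the scatter), whereas a 1.2-fold lower number from compound 2 to compound 3 (0.09 log units; within the scatter). Compound 4 `O=C(CN1CCN(c2nnc(Cc3ccncc3)c3ccccc23)CC1)Nc1cc(C(F)(F)F)ccc1Cl` alters that same group once more: 2-chloro-5-(trifluoromethyl)phenyl in place of 4-fluoro-3-(trifluoromethyl)phenyl on an amide-type nitrogen. All three measured steps bear on this change, as each of them also exchanges one substituted phenyl for another at this position: a 1.7-fold lower number from compound 1 to compound 2 (0.24 log units; within the scatter), a 2.1-fold lower number from compound 1 to compound 3 (0.32 log units; beyond the scatter) and a 1.2-fold lower number from compound 2 to compound 3 (0.09 log units; within the scatter). None of them moved the number by more than a modest amount, so no step beyond the scatter in this assay is anticipated here either. The step expected from this change is a 1.3-fold higher number from compound 3 to compound 4 (0.10 log units; within the scatter). Compound 4 is therefore estimated to give 1400 nM, with a likely range from 600 nM to 3500 nM.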

Compound 4, half-maximal inhibitory concentration: 4810 nM
Estimate against measurement, compound 4: 3.4-fold (0.54 log units) below, and the stated range ends below it.
By their numbers in this assay, from the lowest: compounds 3, 2 and 1 (each within the scatter of the next, the first and the last beyond it); then compound 4.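

In this assay, among these compounds, this position proves able to shift the number more than the earlier exchanges did: a 4.3-fold higher number from compound 3 to compound 4 (0.64 log units; beyond the scatter) is the largest step so far, and a 3.6-fold higher number from compound 2 to compound 4 (0.55 log units; beyond the scatter) and a 2.1-fold higher number from compound 1 to compound 4 (0.32 log units; beyond the scatter) are also beyond the scatter, leaving compound 4 with the weakest inhibition of the four. The groups in compound 3 and compound 4 both carry a trifluoromethyl and have the same count of heavy atoms, so keeping these features did not keep the number. Nothing available explains this step.

The compounds shown do not separate the arrival of chlorine from the loss of fluoro and the changed arrangement on the phenyl, as all of these occur in one step. On these data alone, how a phenyl bearing an amine or a carboxylic acid, or a longer chain in place of the phenyl, would behave also remains open.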